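The source may report more compounds than this note shows. Statements on the series, on what has been measured and on what is new or still open speak of the compounds shown alone.

Compound 2 `CS/C(=N\C(=O)c1cc2ccccc2s1)NC(=O)c1cc2ccccc2s1` is one of three compounds tested in a functional assay on MCF7 cells (Homo sapiens) for cytotoxicity, read by MTT assay, with a stated time of 72 h; a lower number here means a stronger inhibitor of growth, a higher number a weaker inhibitor of growth. In this assay compound 2 gives 43400 nM, the second highest of the three numbers. Its nearest neighbour is compound 1 `C[Se]/C(=N\C(=O)c1cc2ccccc2s1)NC(=O)c1cc2ccccc2s1`, which gives 32700 nM; the step of a 1.3-fold higher number from compound 1 to compound 2 (0.12 log units; within the scatter) lies within the scatter. The furthest is compound 3 `CS/C(=N\C(=O)c1cc(-c2ccccc2)nc2ccccc12)NC(=O)c1cc(-c2ccccc2)nc2ccccc12`, with a different shared core, which gives 87700 nM, a number beyond the scatter from compound 2.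

The compound still to be measured is compound 4 `O=C(/N=C(/NC(=O)c1cc2ccccc2s1)[Se]Cc1ccccc1)c1cc2ccccc2s1`. Its change from compound 2 is a group of 8 heavy atoms (7 carbon, 1 selenium; one six-membered aromatic ring of carbon only) in place of a group of 2 heavy atoms (1 carbon, 1 sulfur; no ring), on a carbon with a double bond to nitrogen. Within the data shown here, only the step from compound 1 to compound 2 bears on this change, since it also swaps sulfur for selenium at the same carbon; that step was within the scatter. Among the measured compounds shown here, no measured pair shows what the entering ring adds, so the step in this assay from compound 2 to compound 4 is expected to be small and of uncertain direction: a 1.2-fold lower number from compound 2 to compound 4 (0.09 log units; within the scatter). Compound 4 is therefore estimated at 35000 nM, within a range from 12000 nM to 100000 nM.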

Compound 4, concentration for total growth inhibition: 62900 nM
Compound 4: the middle estimate sits 1.8-fold (0.25 log units) below what was measured; measured number inside the range.
By their numbers in this assay, from the lowest: compounds 1, 2, 4 and 3 (each within the scatter of the next, the first and the last beyond it).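

In this assay, a group with a six-membered aromatic ring on a carbon with a double bond to nitrogen gives a number within the scatter of the smaller methylsulfanyl group (a 1.4-fold higher number from compound 2 to compound 4 (0.16 log units; within the scatter)). The cleaner comparison keeps selenium in both compounds, with phenyl in place of hydrogen on a saturated chain carbon bound to a selenium atom, and it too stays within the scatter (a 1.9-fold higher number from compound 1 to compound 4 (0.28 log units; within the scatter)). No other measurement is available to explain these numbers.

Going by these compounds, whether an amine or a carboxylic acid on that chain carbon, or a longer chain carrying the ring, would give a step beyond the scatter remains open. The compounds shown also leave open how the same ring-bearing group would compare with sulfur in place of selenium.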